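Swapping the aryl group on the enone chain

The source may report more compounds than this note shows. Statements on the series, on what has been measured and on what is new or still open speak of the compounds shown alone.

Measured compounds and their numbers in a functional assay on DU-145 cells (Homo sapiens) for inhibition, read by trypan blue exclusion, with a stated time of 96 h; a higher number here means a weaker inhibitor of growth, a lower number a stronger inhibitor of growth:
Compound 1 `Cc1cc(C)cc(/C=C(\C(=O)c2ccc(Cl)cc2)S(=O)(=O)Cc2ccc(Cl)cc2)c1` gives 1000 nM.
Compound 2 `Cc1ccc(CS(=O)(=O)/C(=C/c2ccc(N(C)C)cc2)C(=O)c2ccc(Cl)cc2)cc1` gives 50000 nM.
Compound 3 `Cc1ccc(CS(=O)(=O)/C(=C/c2ccc(C)s2)C(=O)c2ccc(Cl)cc2)cc1` gives 25000 nM.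

Compound 3 stands second highest of the three numbers. Its nearest neighbour is compound 2, and the step of a 2.0-fold lower number from compound 2 to compound 3 (0.30 log units; within the scatter) lies within the scatter, so these two cannot be ranked against each other. Compound 1 sits far below both, beyond the scatter.

Compound 4 `Cc1ccc(CS(=O)(=O)/C(=C/c2cc(C)cc(C)c2)C(=O)c2ccc(Cl)cc2)cc1` arises from compound 3 by one change: 3,5-dimethylphenyl in place of 5-methylthiophen-2-yl on a double-bonded chain carbon bound to a double-bonded chain carbon. Among the compounds with values here, no measured step covers exactly this exchange. Within the data shown here, the only measured step, the one from compound 2 to compound 3, concerns a different pair of groups and was within the scatter. The 3,5-dimethylphenyl group that enters is also present in compound 1, the compound with the lowest number, though compound 1 and compound 4 differ elsewhere too, so this is only a pointer. A lower number than that of compound 3 is therefore expected, and the estimated step is a 10-fold lower number from compound 3 to compound 4 (1.00 log units; beyond the scatter). Compound 4 is expected to give about 2500 nM, within a range of 800 nM to 12000 nM.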

Compound 4, concentration for 50% growth inhibition: 10000 nM
The estimate for compound 4 lay 4.0-fold (0.60 log units) below the measured number; low and high end bracket the measured number.
By their numbers in this assay, from the lowest: compound 1; then compound 4; then compounds 3 and 2 (each within the scatter of the next).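

In this assay, the group at this place on a double-bonded chain carbon bound to a double-bonded chain carbon now makes a difference beyond the scatter, though a modest one: 3,5-dimethylphenyl in place of 5-methylthiophen-2-yl gives a 2.5-fold lower number from compound 3 to compound 4 (0.40 log units; beyond the scatter), and 3,5-dimethylphenyl in place of 4-(dimethylamino)phenyl gives a 5.0-fold lower number from compound 2 to compound 4 (0.70 log units; beyond the scatter). The 3,5-dimethylphenyl group alone does not bring the low number of compound 1, since methyl in place of chloro on an aromatic carbon gives a 10-fold higher number from compound 1 to compound 4 (1.00 log units; beyond the scatter), so that second place matters too. Nothing measured here explains either effect.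

On these data alone, it remains open whether chloro in place of methyl would lower the number equally with 5-methylthiophen-2-yl or 4-(dimethylamino)phenyl on the chain. How a plain phenyl or a pyridine ring would compare at the chain carbon is also unknown.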